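Fluorophenyl piperazine sulfonamides on the shared core

The compounds below may be only part of what the source reports. "The series", "measured", "known", "first", "only" and "open" are said of these compounds alone.

Compound 3 `CCCn1c(=O)[nH]c2nc(-c3ccc(S(=O)(=O)N4CCN(c5cccc(F)c5)CC4)cc3)[nH]c2c1=O` is measured in an assay on CHO cells for displacement of a labelled ligand from adenosine receptor A1 (Homo sapiens), read by scintillation counting, with a stated time of 90 min, in the presence of a further agent that is not named here (a higher number here means a weaker inhibitor, a lower number a stronger inhibitor), only as a limit of the assay, > 1000 nM. Compound 1 `CCCn1c(=O)c2[nH]c(-c3ccc(S(=O)(=O)N4CCN(c5ccc(Cl)cc5)CC4)cc3)nc2n(CC)c1=O` likewise gives only a limit, > 1000 nM. Compound 2 `CCCn1c(=O)[nH]c2nc(-c3ccc(S(=O)(=O)N4CCN(c5ccccc5Br)CC4)cc3)[nH]c2c1=O` also gives only a limit, > 1000 nM. For the measured compounds named here, the single one-place step, a step that the two limits leave unreadable from compound 2 to compound 3, is therefore unreadable, and every value shown sits at the limit of > 1000 nM in this assay, at which 3 of the 3 values shown sit. Compound 4 `CCCn1c(=O)[nH]c2nc(-c3ccc(S(=O)(=O)N4CCN(c5ccc(F)cc5)CC4)cc3)[nH]c2c1=O` differs from compound 3 by 4-fluorophenyl in place of 3-fluorophenyl on an amine nitrogen in a ring. Going by the values given here, no measured step bears on this change with a readable size, and nothing shows a compound leaving the limit. Compound 4 is thus expected to remain at the limit, estimated at 3000 nM with a range from 1000 nM to 30000 nM. The expected step, a step that the limit leaves unreadable from compound 3 to compound 4, is an estimate carrying no readable direction.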

Compound 4, inhibition constant: > 1000 nM
Compound 4 was reported as a limit; the forecaster's own chance of this, stated with the estimate: 85%; the middle value is on the limit's open side.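

Compound 4 is a limit like compound 2 and compound 3, so neither step into compound 4 can be read: the limit of > 1000 nM in this assay, at which 4 of the 4 values shown sit. The compounds shown leave open whether 3-fluorophenyl and 4-fluorophenyl differ at all in this assay.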